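Trimethoxyphenyl for chlorophenyl on an imidazolone chalcone

This account rests on a few compounds, and the source may have more. Where it says the series, first, only, none or still open, it means among the compounds named here.

Three compounds share a core in which a chalcone carries an imidazolone bearing an aryl group. Compound 1 `COc1cc(/C=C/C(=O)c2cccc(-n3cc(-c4ccc(Cl)cc4)[nH]c3=O)c2)cc(OC)c1OC` gives 5450 nM in a functional assay on KM12 cells (Homo sapiens) for inhibition (on this read-out higher numbers stand for weaker inhibition of growth and lower numbers for stronger inhibition of growth), the highest number of the three; compound 2 `O=C(/C=C/c1cccc(O)c1)c1cccc(-n2cc(-c3ccccc3)[nH]c2=O)c1` gives 1830 nM and compound 3 `COc1ccc(-c2cn(-c3cccc(C(=O)/C=C/c4ccc(O)c(OC)c4)c3)c(=O)[nH]2)cc1` gives 1770 nM, and both gaps to compound 1 lie beyond the scatter. Compound 4 `COc1cc(/C=C/C(=O)c2cccc(-n3cc(-c4cc(OC)c(OC)c(OC)c4)[nH]c3=O)c2)cc(OC)c1OC` has not been measured; it differs from compound 1 in one place: 3,4,5-trimethoxyphenyl in place of 4-chlorophenyl on an aromatic carbon. Among the measured compounds shown here, no measured pair shows this exact change, and compounds 2 and 3 also differ elsewhere. A step of modest size toward stronger inhibition is expected from compound 1 to compound 4, a 1.6-fold lower number from compound 1 to compound 4 (0.19 log units; within the scatter). Compound 4 is therefore estimated at 3500 nM, within 1200 nM to 10000 nM.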

Compound 4, concentration for 50% growth inhibition: 1120 nM
For compound 4 the middle estimate is 3.1-fold (0.49 log units) above the measured one; measured number below the stated range.
By their numbers in this assay, from the lowest: compounds 4, 3 and 2 (each within the scatter of the next); then compound 1.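

On an aromatic carbon of the five-membered aromatic ring with 2 nitrogen, 3,4,5-trimethoxyphenyl in place of 4-chlorophenyl gives a 4.9-fold lower number from compound 1 to compound 4 (0.69 log units; beyond the scatter) in this assay. Among the compounds shown here, this shows that, with the rest of compound 1 unchanged, the aryl group at this position alone moves the read-out beyond the scatter, which the earlier compounds, differing in more than one place, could not show. No evidence on hand explains this step.

From the compounds shown here alone, it remains open how an amine or a carboxylic acid on this phenyl ring would compare. Going by these compounds, whether the step carries over to other groups on the chalcone end also remains open.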